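Replacing formyl with a pyrrolidinyl-methyl group: an expectation

The source may hold more compounds than are shown below. What is called first, only, known or untested is meant among the compounds shown, and "the series" means these compounds.

Compound 1 `CN1CCN(CCCN(c2nc3cc(F)c(F)cc3[nH]2)[C@@H]2CC[C@]3(c4cccc(C#N)c4)C[C@H]23)CC1` gives 20.7 nM in an assay on isolated protein for binding affinity to melanin-concentrating hormone receptor 1 (Homo sapiens); a higher number here means a weaker inhibitor, a lower number a stronger inhibitor.
Compound 2 `CN1CCN(CCCN(c2nc3cc(Cl)c(Cl)cc3[nH]2)[C@@H]2CC[C@]3(c4cccc(C=O)c4)C[C@@H]3C2)CC1` gives 13.7 nM in this assay.
Compound 3 `CN1CCN(CCCN(c2nc3cc(F)c(F)cc3[nH]2)[C@@H]2CC[C@]3(c4cccc(C=O)c4)C[C@@H]3C2)CC1` gives 16.3 nM in this assay.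

Among these three numbers compound 3 holds the second highest place, yet its gaps to the others are small: compound 2 stands nearest, and compound 1 furthest, with both differences within the usual scatter of repeated measurements. For the measured compounds named here, the one step computed from structure, a 1.2-fold higher number from compound 2 to compound 3 (0.08 log units; within the scatter), touches the halogens on the benzimidazole and lies within the scatter as well.

Compound 4 `CN1CCN(CCCN(c2nc3cc(F)c(F)cc3[nH]2)[C@@H]2CC[C@]3(c4cccc(CN5CCC[C@H]5CO)c4)C[C@@H]3C2)CC1` keeps the whole framework of compound 3 and changes only the group on the aryl ring: (2-(hydroxymethyl)pyrrolidin-1-yl)methyl in place of formyl on an aromatic carbon. No measured pair among these compounds varies that position, so no step in this assay speaks directly to this change. The closest guide is that three otherwise different compounds all sit close together, which suggests that the shared core carries most of the binding. The change from compound 3 to compound 4 is therefore expected to give a step of a 1.1-fold higher number from compound 3 to compound 4 (0.04 log units; within the scatter), with no clear direction beyond the scatter. Compound 4 is estimated at 18 nM, within a range from 5 nM to 70 nM.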

Compound 4, inhibition constant: 3000 nM
Compound 4: the middle estimate sits 170-fold (2.22 log units) below what was measured, and the stated range ends below it.
By their numbers in this assay, from the lowest: compounds 2, 3 and 1 (each within the scatter of the next); then compound 4.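

This aromatic carbon, meta to a large group, is no neutral place to make a change, which the three earlier compounds could not show because none of their pairs varied it. In this assay the swap of formyl for (2-(hydroxymethyl)pyrrolidin-1-yl)methyl gives a 180-fold higher number from compound 3 to compound 4 (2.26 log units; beyond the scatter) even though the rest of compound 3 stays the same, so the close grouping of the earlier numbers did not mean that this position tolerates any group. The entering group differs from formyl in several ways at once, with more heavy atoms, a five-membered non-aromatic ring, a hydrogen-bond donor and a defined stereocentre, and no measurement available here explains which of these, if any, accounts for the step.

Going by these compounds, what remains open is which part of the new group goes with the weaker binding: a plain pyrrolidin-1-ylmethyl group would test the ring without its hydroxymethyl arm, while a simple hydroxymethyl group on the aromatic carbon would test the arm without the ring. Also open, on these data alone, is whether the opposite stereocentre in the pyrrolidine, or a small amine such as aminomethyl, would behave the same way at this position.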